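Benzyl to 4-chlorophenyl on the shared core

The source may hold more compounds than are shown below. What is called first, only, known or untested is meant among the compounds shown, and "the series" means these compounds.

The series keeps one core, seen in compound 3 `Nc1cccc(-c2cn3nc(Cc4ccccc4)sc3n2)c1`, and varies the group on an aromatic carbon of the five-membered aromatic ring with 2 nitrogen and 1 sulfur. In a functional assay on HeLa cells (Homo sapiens) for inhibition, read by cell counting, with a stated time of 4 days (a lower number here means a stronger inhibitor, a higher number a weaker inhibitor), compound 3 gives 24000 nM, the lowest of the two numbers measured, with compound 2 `Nc1cccc(-c2cn3nc(Cc4ccc(Cl)cc4)sc3n2)c1` closest at 25000 nM. Compound 1 `Nc1cccc(-c2cn3nc(-c4ccc(F)cc4)sc3n2)c1` carries 4-fluorophenyl and in this assay compound 1 returns only a limit, >= 250000 nM. The step of an at least 10-fold lower number from compound 1 to compound 3 (1.01 log units; beyond the scatter) thus sets only a floor on how far benzyl lowers the number, while the step of a 1.0-fold lower number from compound 2 to compound 3 (0.02 log units; within the scatter) shows chloro against hydrogen on the benzyl ring making no difference beyond the scatter.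

Compound 4 `Nc1cccc(-c2cn3nc(-c4ccc(Cl)cc4)sc3n2)c1` is not yet measured. It differs from compound 3 by 4-chlorophenyl in place of benzyl on an aromatic carbon. This undoes the aryl-to-benzyl change and adds a chloro, which in the step of a 1.0-fold lower number from compound 2 to compound 3 (0.02 log units; within the scatter) was indistinguishable from hydrogen. The step from compound 1 bears most directly, and the bound the limit of >= 250000 nM in this assay, at which 1 of the 3 values shown sits, suggests compound 4 may again sit at that limit. A large rise is expected, a 10-fold higher number from compound 3 to compound 4 (1.02 log units; beyond the scatter), and compound 4 is estimated at 250000 nM, within the range 80000 nM to 600000 nM.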

Compound 4, half-maximal inhibitory concentration: 160000 nM
The estimate for compound 4 lay 1.6-fold (0.19 log units) above the measured number, within the range that was stated.
By their numbers in this assay, from the lowest: compounds 3 and 2 (each within the scatter of the next); then compound 4. At a limit, above all of these: compound 1.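

Working note on the benzyl position: in this assay, 4-chlorophenyl in place of benzyl on this aromatic carbon gives the first fully measured size for the loss of benzyl (a 6.7-fold higher number from compound 3 to compound 4 (0.82 log units; beyond the scatter)), where the earlier pair offered only a floor. This step is beyond the scatter, so benzyl is favoured over a directly attached aryl group on a measured basis, at least for compound 3 and compound 4, whereas chloro in place of hydrogen on the benzyl ring had shown no difference beyond the scatter. Chloro and fluoro on the directly attached phenyl ring cannot be ranked (an at least 1.5-fold lower number from compound 1 to compound 4 (0.19 log units; that floor lies within the scatter)) as that floor lies within the scatter, and the value for compound 1 remains a limit: the limit of >= 250000 nM in this assay, at which 1 of the 4 values shown sits.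

The compounds shown leave open whether a longer chain such as phenethyl, or an amine link in place of the benzyl carbon, would lower the number further than benzyl does. Also open, as far as these compounds go, is how the number responds to a methoxy group or a carboxylic acid on the benzyl ring, and to any replacement of the amino group, which stays constant across the shared core.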